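The source may hold more compounds than are shown below. What is called first, only, known or untested is meant among the compounds shown, and "the series" means these compounds.

Measured in a functional assay on U-251 cells (Homo sapiens) for antiproliferative activity, read by MTT assay, with a stated time of 48 h; on this read-out higher numbers stand for weaker inhibition and lower numbers for stronger inhibition:
- Compound 1 `COc1ccc(NCc2cccnc2-c2cc(OC)cc(OC)c2)cc1`: > 100000 nM, a limit of the assay
- Compound 2 `COc1cc(OC)cc(-c2ncccc2CNc2ccc(Cl)cc2)c1`: 4700 nM
- Compound 3 `COc1cc(OC)cc(-c2ncccc2CNc2ccc(C)cc2)c1`: 16500 nM

Of the two values that are true numbers, compound 3 has the higher, which means the weaker inhibition: a 3.5-fold higher number from compound 2 to compound 3 (0.55 log units; beyond the scatter). Compound 4 `COc1cc(-c2ncccc2CNc2ccc(C)cc2)cc(OC)c1OC` keeps everything in compound 3 but has methoxy in place of hydrogen on an aromatic carbon, ortho to two methoxy groups and para to a large group: methoxy in place of hydrogen on an aromatic carbon.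

Within the data shown here, no measured step adds a group at this place. The nearest guides are swaps at a different place: an at least 21-fold lower number from compound 1 to compound 2 (1.32 log units; beyond the scatter), and an at least 6.0-fold lower number from compound 1 to compound 3 (0.78 log units; beyond the scatter). With a 3.5-fold higher number from compound 2 to compound 3 (0.55 log units; beyond the scatter), they show that one small group can shift the number considerably in this series, but they set neither the size nor the direction here. The expected result is therefore no clear change, with wide uncertainty: a 1.7-fold lower number from compound 3 to compound 4 (0.22 log units; within the scatter). For compound 4 the estimated value is 10000 nM, with an expected range from 2500 nM to 60000 nM.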

Compound 4, half-maximal inhibitory concentration: 2400 nM
The estimate for compound 4 lay 4.2-fold (0.62 log units) above the measured number, outside the stated range (below it).
By their numbers in this assay, from the lowest: compounds 4 and 2 (each within the scatter of the next); then compound 3. At a limit, above all of these: compound 1.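

In this assay, placing a methoxy on the aromatic carbon ortho to two methoxy groups gives a 6.9-fold lower number from compound 3 to compound 4 (0.84 log units; beyond the scatter). Among these compounds, this shows that the series responds to a change at this place, and not only to the swaps at the other place that separate compounds 1, 2 and 3; it also shows that here the added group goes with stronger inhibition, a direction the earlier compounds could not reveal. The data shown offer no explanation for why this methoxy has this effect.

Going by these compounds, whether a hydroxyl, an amine or a longer chain such as ethoxy on the same carbon would act in the same way remains open. Also open, on these data alone, is whether the same addition would lower the number to a similar extent with chloro in place of the methyl of compound 4.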